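This account rests on a few compounds, and the source may have more. Where it says the series, first, only, none or still open, it means among the compounds named here.

Of the compounds shown here, three that share one core have been measured in a physicochemical assay for lipophilicity, using the shake flask method, in phosphate buffer, measured as octanol-water partition, with a stated time of 30 min, at pH 7.4; a lower number here means a more polar compound, a higher number a more lipophilic compound. Compound 1 `Cc1cc(-c2cnc(NCc3c(F)ccc4c3CCO4)c3cn[nH]c(=O)c23)n(C)n1` gives 3, and compound 3 `CNC(=O)c1ccc(-c2cnc(NCc3c(F)ccc4c3CCO4)c3cn[nH]c(=O)c23)c(C)n1` gives 2.9. Among the measured compounds shown here, the single step between them in which one place changes, a number 0.10 log units lower from compound 1 to compound 3 (within the scatter), exchanges one ring group for another at an aromatic carbon of the core and leaves the read-out essentially where it was. Compound 2 `O=C(Nc1ccccc1)c1cnc(NCc2c(F)ccc3c2CCO3)n2cnnc12` gives 4.1, the highest of the three numbers, clearly above compound 1 and clearly above compound 3.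

Compound 4 `O=C(Nc1cnc(NCc2c(F)ccc3c2CCO3)n2cnnc12)c1ccccc1` has not yet been measured. It differs from compound 2 by benzamido in place of phenylcarbamoyl on an aromatic carbon, so the two have the same atoms, joined differently. For the measured compounds named here, no measured step resembles this change: the one step known, from compound 1 to compound 3, replaces a whole ring group and stayed within the scatter. With the atom count unchanged and nothing pointing either way, the step of a number 0.10 log units lower from compound 2 to compound 4 (within the scatter) is expected to lie within the scatter. Compound 4 is therefore estimated at 4, with a likely range from 3.5 to 4.5.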

Compound 4, distribution coefficient: 3
Estimate against measurement, compound 4: 1.00 log units above; measured number below the stated range.
By their numbers in this assay, from the lowest: compounds 3, 1 and 4 (each within the scatter of the next); then compound 2.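

Reversing the amide at this aromatic carbon, with benzamido in place of phenylcarbamoyl, gives a number 1.10 log units lower from compound 2 to compound 4 (beyond the scatter) in this assay even though the two groups have the same heavy atoms, the same aromatic ring and the same counts of hydrogen-bond donors and acceptors. Among the compounds shown here, at this position, then, the way the atoms are joined can change the read-out on its own, which the one earlier step, an exchange of one whole ring group for another, could not show. Nothing available explains why this step is so large.

Going by these compounds, it remains open whether an amine, a carboxylic acid or a longer chain at this position would give a number closer to compound 2 or to compound 4. Whether the same reversal would have a similar effect on the core of compound 1 is also unknown.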